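Removing Two Methyl Groups from a Potent Channel Agonist

The source may hold more compounds than are shown below. What is called first, only, known or untested is meant among the compounds shown, and "the series" means these compounds.

Measured compounds:
compound 1, `CCN(Cc1ccco1)C(=O)COc1ccc(C)cc1`, 489 nM
compound 2, `Cc1ccc(OCC(=O)N(Cc2cccs2)c2c(C)n[nH]c2C)cc1`, 0.3 nM
compound 3, `CCN(Cc1cccs1)C(=O)c1cc2cc(C)ccc2[nH]1`, 2010 nM

Of the compounds shown here, three have been tested in an assay on HEK293 cells for agonist activity at transient receptor potential cation channel subfamily M member 8 (Homo sapiens), read by fluorescence and calcium flux, with a stated time of 15 min; a lower number here means that less compound is needed, a higher number that more compound is needed for the effect. Compound 2 gives 0.3 nM, the lowest number of the three and beyond the scatter from both others: compound 1 gives 489 nM and compound 3 gives 2010 nM. Among these, compound 2 is therefore the most potent.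

Compound 4, `Cc1ccc(OCC(=O)N(Cc2cccs2)c2cn[nH]c2)cc1`, has not yet been measured. It differs from compound 2 in one place: 1H-pyrazol-4-yl in place of 3,5-dimethyl-1H-pyrazol-4-yl on an amide-type nitrogen. Among the compounds with values here, no pair of measured compounds differs by a single change, so no measured step gives a direct guide to this one. The change removes two methyl groups while keeping the same aromatic ring, donor and acceptor. Because compound 2 gives 0.3 nM, a very low number, the expectation is that compound 4 will need somewhat more compound, a step of a 10-fold higher number from compound 2 to compound 4 (1.00 log units; beyond the scatter) beyond the scatter but modest. Compound 4 is estimated at 3 nM, within the range 0.5 nM to 30 nM.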

Compound 4, half-maximal effective concentration: 1.4 nM
Beside the measured number, compound 4's estimate is 2.1-fold (0.33 log units) above it; measured number inside the range.
By their numbers in this assay, from the lowest: compound 2; then compound 4; then compound 1; then compound 3.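

Taking both methyl groups off the 3,5-dimethyl-1H-pyrazol-4-yl group on the amide-type nitrogen gives a 4.7-fold higher number from compound 2 to compound 4 (0.67 log units; beyond the scatter) in this assay, the first single change that can be read in this set. The two methyl groups therefore count at this position, yet they are not required for high potency, as compound 4 still gives 1.4 nM with the bare 1H-pyrazol-4-yl group. No measurement here explains why the number rises, so the step stands as an observation only.

The compounds shown leave open whether a single methyl group, as in a 3-methyl-1H-pyrazol-4-yl group, would be enough to recover the lower number. They also leave open how an ethyl group or an amine on the same ring, or a phenyl ring in place of the pyrazole, would behave.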